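From Benzyl to Allyl on a Shared Core

The compounds below may be only part of what the source reports. "The series", "measured", "known", "first", "only" and "open" are said of these compounds alone.

In a functional assay on KB 3-1 cells (Homo sapiens) for cytotoxicity, read by MTT assay, with a stated time of 72 h (on this read-out lower numbers stand for stronger inhibition and higher numbers for weaker inhibition), compound 1 `O=C1Nc2ccccc2/C1=N/NC(=S)Nc1cccc2ccccc12` gives 5120 nM and compound 2 `O=C1Nc2ccccc2/C1=N/NC(=S)NCc1ccccc1` gives 11700 nM as the higher of the two numbers. Compound 2 therefore stands as the weaker of this pair, by a gap beyond the usual scatter. Within the data shown here, compound 3 `C=CCNC(=S)N/N=C1\C(=O)Nc2ccccc21` has no measurement yet. It keeps the shared core and changes one group (vinyl in place of phenyl on a saturated chain carbon bound to an amide-type nitrogen). In words, vinyl replaces phenyl on a saturated chain carbon bound to an amide-type nitrogen, so benzyl becomes allyl. Among the measured compounds shown here, no measured pair shows this change, so any prediction is a judgement with little support. In this assay a small step towards a higher number is expected, perhaps no larger than the scatter (a 1.5-fold higher number from compound 2 to compound 3 (0.19 log units; within the scatter)). The estimate for compound 3 is 18000 nM (expected range 7000 nM to 45000 nM).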

Compound 3, half-maximal inhibitory concentration: 26100 nM
Beside the measured number, compound 3's estimate is 1.5-fold (0.16 log units) below it; measured number inside the range.
By their numbers in this assay, from the lowest: compound 1; then compound 2; then compound 3.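

In this assay, turning benzyl into allyl by putting vinyl in place of phenyl gives a 2.2-fold higher number from compound 2 to compound 3 (0.35 log units; beyond the scatter), a modest step but one that lies beyond the usual scatter. This pair is the only direct reading of this change shown here. It indicates that the group on a saturated chain carbon bound to an amide-type nitrogen can alter the number, with the ring-free allyl compound giving the weaker result. No measurement shown here accounts for the shift, so its origin remains unexplained.

A single pair cannot separate the loss of the aromatic ring from the gain of the double bond outside it. A propyl chain or a cyclohexylmethyl group at this place would help to tell those two apart.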